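The source may hold more compounds than are shown below. What is called first, only, known or untested is meant among the compounds shown, and "the series" means these compounds.

In a functional assay on RKOp27 cells (Homo sapiens) for cytotoxicity, read by MTT assay, with a stated time of 3 days (a higher number here means a weaker inhibitor, a lower number a stronger inhibitor), the measured compounds stand as follows

- Compound 1 `CCNc1nc(SCc2nc3ccccc3[nH]2)nc(-c2ccccc2)c1C#N` gives 7.35 nM
- Compound 2 `N#Cc1c(Nc2nccs2)nc(SCc2nc3ccccc3[nH]2)nc1-c1ccccc1` gives 3.2 nM
- Compound 3 `N#Cc1c(NC(N)=S)nc(SCc2nc3ccccc3[nH]2)nc1-c1ccccc1` gives 2.63 nM

Compound 2 belongs to the lower pair of these numbers: a 1.2-fold lower number from compound 2 to compound 3 (0.09 log units; within the scatter) stays within the scatter, while a 2.3-fold lower number from compound 1 to compound 2 (0.36 log units; beyond the scatter) goes beyond it.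

Compound 4 `CN1CCN(c2nc(SCc3nc4ccccc4[nH]3)nc(-c3ccccc3)c2C#N)CC1` carries 4-methylpiperazin-1-yl in place of (1,3-thiazol-2-yl)amino on an aromatic carbon, ortho to a cyano group (4-methylpiperazin-1-yl in place of (1,3-thiazol-2-yl)amino on an aromatic carbon). For the measured compounds named here, the measured steps all change what sits on a nitrogen on an aromatic ring, and no measured compound has a non-aromatic ring here, so they guide this change only loosely. They were small to modest, as a 2.8-fold lower number from compound 1 to compound 3 (0.45 log units; beyond the scatter) shows. Only compound 1, with its ethyl, gives a clearly higher number, at 7.35 nM, and compound 3 shows that lacking an aromatic ring does not always raise it. The lean is therefore only slightly upward in this assay. The expected change is a 1.9-fold higher number from compound 2 to compound 4 (0.27 log units; within the scatter), a modest step towards a weaker inhibitor. Compound 4 is estimated at 6 nM, within an expected range of 2 nM to 20 nM.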

Compound 4, half-maximal inhibitory concentration: 5.4 nM
Estimate against measurement, compound 4: 1.1-fold (0.05 log units) above; the range from low to high includes it.
By their numbers in this assay, from the lowest: compounds 3, 2, 4 and 1 (each within the scatter of the next, the first and the last beyond it).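

In this assay, compound 4 is the first compound shown with a non-aromatic ring at this position, and its 4-methylpiperazin-1-yl brings no hydrogen-bond donor, unlike the (1,3-thiazol-2-yl)amino it replaces. Even so, a 1.7-fold higher number from compound 2 to compound 4 (0.23 log units; within the scatter) stays within the scatter, as does a 1.4-fold lower number from compound 1 to compound 4 (0.13 log units; within the scatter), so the change to this ring leaves the number close to those of both compounds. Only a 2.1-fold higher number from compound 3 to compound 4 (0.31 log units; beyond the scatter) passes the scatter, and that step is modest.

Nothing measured here explains these differences. As far as these compounds go, it remains open whether a piperazine without its methyl, or a morpholine ring with oxygen in place of the second ring nitrogen, would stay in this range, and a single ring cannot show which of its features matter.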